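Series notes: arylamino variation on the shared urea core

A few compounds are considered here, and "the series" means these few. Any claim that something is new, unique, unknown or untested is made for them only; others in the source may bear on it.

Compound 3 `COc1cc(NC(=O)Nc2cc(Nc3ccc(OC)c(C)c3)ncn2)cc(OC)c1` stands lowest of the three measured compounds. In a functional assay on NCI-H1581 cells (Homo sapiens) for inhibition, read by MTT assay, with a stated time of 48 h, tested at 10 uM (a lower number here means less inhibition, a higher number more inhibition at the concentration tested (going by the name of the read-out)), compound 3 gives 19.7%. The nearest number belongs to compound 1 `CCc1ccc(Nc2cc(NC(=O)Nc3cc(OC)cc(OC)c3)ncn2)cc1`, which in this assay gives 32.7%; the step reads a number 13 percentage points lower from compound 1 to compound 3 (beyond the scatter). Furthest is compound 2 `COc1cc(NC(=O)Nc2cc(Nc3ccc(F)c(Cl)c3)ncn2)cc(OC)c1`, which in this assay gives 53%; that step reads a number 33.3 percentage points lower from compound 2 to compound 3 (beyond the scatter). Between the two higher compounds the step reads a number 20.3 percentage points higher from compound 1 to compound 2 (beyond the scatter).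

Compound 4 `COc1cc(NC(=O)Nc2cc(Nc3cc(C)cc(F)c3)ncn2)cc(OC)c1` has not been measured in this assay. It differs from compound 3 in one place: 3-fluoro-5-methylphenyl in place of 4-methoxy-3-methylphenyl on a nitrogen on an aromatic ring The measured steps bearing on this change are the two into compound 3, one modest and one large, both downward, from the 4-ethylphenyl of compound 1 and from the 3-chloro-4-fluorophenyl of compound 2. Compound 4 drops the 4-methoxy-3-methylphenyl of compound 3 and carries a fluorine on its aryl ring, as compound 2 does, while keeping a methyl, as compound 3 and compound 1 do. An upward step is therefore expected, smaller than the large step from compound 2 and broadly in line with the modest step from compound 1. The estimate for compound 4 in this assay is 40%, with a range from 25% to 56%; the step expected is a number 20.3 percentage points higher from compound 3 to compound 4 (beyond the scatter).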

Compound 4, a percentage reported as inhibition, at one concentration (the size of the read-out at that concentration, not a potency): 28.3%
For compound 4 the middle estimate is 11.7 percentage points above the measured one; the range from low to high includes it.
By their numbers in this assay, from the lowest: compounds 3, 4 and 1 (each within the scatter of the next, the first and the last beyond it); then compound 2.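

In this assay this change at the nitrogen on the aromatic ring gives no readable shift, with a number 8.6 percentage points higher from compound 3 to compound 4 (within the scatter) and a number 4.4 percentage points lower from compound 1 to compound 4 (within the scatter), so the 3-fluoro-5-methylphenyl group cannot be told apart from the 4-methoxy-3-methylphenyl or the 4-ethylphenyl group. A fluorine on the aryl ring does not by itself go with the reading of compound 2, as the comparison shows a number 24.7 percentage points lower from compound 2 to compound 4 (beyond the scatter), and compound 2 with its 3-chloro-4-fluorophenyl group is now beyond the scatter of all three other compounds. No measured information on these compounds accounts for that separation.

Still open, from the compounds shown here alone, is whether the chlorine of compound 2, its fluorine, or the two together carry its reading, which a phenyl group bearing chlorine alone or fluorine alone on this nitrogen would help to separate. Also open, going by these compounds, is how an aryl group carrying an amine such as morpholine, or a carboxylic acid, would read at this position.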